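The source may report more compounds than this note shows. Statements on the series, on what has been measured and on what is new or still open speak of the compounds shown alone.

Of the compounds shown here, two have been measured so far in a functional assay on cells (Melanoma cell, Homo sapiens) for inhibition; on this read-out higher numbers stand for weaker inhibition of growth and lower numbers for stronger inhibition of growth. Compound 1 `Cc1cc(-c2nc3sc(C)cn3c2/C=N/NC(=N)N)c(C)s1` gives 15100 nM, and compound 2 `N=C(N)N/N=C/c1c(-c2cc(Cl)sc2Cl)nc2n1CCS2` gives 20400 nM. These two values lie within the usual scatter of repeated measurements, so compound 1 stands level with compound 2 and neither can be ranked above the other.

Compound 3 `Cc1cc(-c2nc3sccn3c2/C=N/NC(=N)N)c(C)s1` is a close relative of compound 1 that has not yet been measured. The two differ in a single place: hydrogen in place of methyl on an aromatic carbon. In plain terms, compound 3 has hydrogen in place of methyl on an aromatic carbon.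

Within the data shown here, no measured pair isolates this change, so the data give no direct guide to its size or direction. The change is small, and no step beyond the scatter is expected in this assay. The estimated step of a 1.1-fold higher number from compound 1 to compound 3 (0.03 log units; within the scatter) reflects that expectation and remains uncertain. For compound 3, the expected value is 16000 nM, with an estimated range from 7000 nM to 36000 nM.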

Compound 3, concentration for total growth inhibition: 30900 nM
Compound 3: the middle estimate sits 1.9-fold (0.29 log units) below what was measured, and the stated range covers the measured number.
By their numbers in this assay, from the lowest: compounds 1, 2 and 3 (each within the scatter of the next, the first and the last beyond it).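

In this assay, replacing the methyl on the aromatic carbon next to the ring sulfur with hydrogen gives a 2.0-fold higher number from compound 1 to compound 3 (0.31 log units; beyond the scatter), the first measured sign of what this position contributes. The direction is now clear: a higher number means weaker inhibition of growth, so within this pair the compound carrying the methyl is the stronger one, and even a single carbon at this position can shift the result, although the step is modest and only just clears the usual scatter of repeated measurements. Nothing measured here explains why the number moves in this direction.

This single pair cannot show whether the trend continues with a larger group on the same carbon, such as an ethyl or a longer chain, or whether a different kind of group, such as an amine or a methoxy, would bring a similar or opposite step. It also leaves open whether the methyl would have the same effect on a different core or with a different group in place of the dimethyl-substituted ring shared by compound 1 and compound 3.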